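Swapping Fluoro for Methyl in a Shared Core

This account rests on a few compounds, and the source may have more. Where it says the series, first, only, none or still open, it means among the compounds named here.

Three measured compounds share one core and differ at a single aromatic carbon. Compound 1 `NS(=O)(=O)c1ccc(N2N=C(c3ccc(Br)cc3)CC2c2cn(-c3ccccc3)nc2-c2ccc(F)cc2)cc1` carries bromo there, and in an ADME assay on Vero cells (Chlorocebus sabaeus) for cytotoxicity, read by MTT assay, with a stated time of 72 h (on this read-out higher numbers stand for lower toxicity in this test and lower numbers for higher toxicity in this test), compound 1 gives 49400 nM. Compound 3 `NS(=O)(=O)c1ccc(N2N=C(c3ccc(O)cc3)CC2c2cn(-c3ccccc3)nc2-c2ccc(F)cc2)cc1` carries hydroxy, and in this assay compound 3 gives 32000 nM. Compound 2 `Cc1ccc(C2=NN(c3ccc(S(N)(=O)=O)cc3)C(c3cn(-c4ccccc4)nc3-c3ccc(F)cc3)C2)cc1` carries methyl, and in this assay compound 2 gives > 90600 nM, which is a limit of the assay rather than a number. Compound 2 thus stands at the upper edge of what the test reports (the limit of > 90600 nM in this assay, at which 1 of the 3 values shown sits). The measured steps read an at least 1.8-fold higher number from compound 1 to compound 2 (0.26 log units; that floor lies within the scatter), a 1.5-fold lower number from compound 1 to compound 3 (0.19 log units; within the scatter) and an at least 2.8-fold lower number from compound 2 to compound 3 (0.45 log units; beyond the scatter).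

Compound 4 `Cc1ccc(C2=NN(c3ccc(S(N)(=O)=O)cc3)C(c3cn(-c4ccccc4)nc3-c3ccc(C)cc3)C2)cc1` differs from compound 2 by methyl in place of fluoro on an aromatic carbon. Among the compounds with values here, no measured step is this exact change; the nearest one, which also introduced a methyl on an aromatic carbon, gave an at least 1.8-fold higher number from compound 1 to compound 2 (0.26 log units; that floor lies within the scatter), a floor within the scatter. No step beyond the scatter is therefore expected in this assay. Compound 4 is expected to give 95000 nM, between 45000 nM and 200000 nM, most likely again only as a limit. The expected step is a step that the limit leaves unreadable from compound 2 to compound 4.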

Compound 4, half-maximal cytotoxic concentration: > 41400 nM
Compound 4: a limit, no number; the forecaster's own chance of this, stated with the estimate: 60%; the middle value is on the limit's open side.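

In this assay, within the data shown here, compound 2 and compound 4 both give limits, not numbers, and no step between them can be read. The compounds shown leave open whether methyl in place of fluoro on an aromatic carbon changes the read-out at all, and in which direction.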